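Moving the ring nitrogen in a pyridine-bearing aldehyde dehydrogenase inhibitor

This account rests on a few compounds, and the source may have more. Where it says the series, first, only, none or still open, it means among the compounds named here.

Of the compounds shown here, three have so far been measured in an assay on isolated protein for inhibition of aldehyde dehydrogenase 1A1 (Homo sapiens); a higher number here means a weaker inhibitor, a lower number a stronger inhibitor. Compound 1 `Cn1ncc2c(=O)n(-c3ccccc3)c(SCc3cccc(F)c3)cc21` gives 240 nM. Compound 2 `CC(Sc1nc2c(cnn2C)c(=O)n1-c1ccccc1)c1ccccn1` gives 242 nM. Compound 3 `O=c1c2cncn2nc(SCc2cccc(F)c2)n1-c1ccccc1`, which is built on a different core from the other two, gives 2200 nM. Among these three numbers compound 2 stands second highest. Its number and that of compound 1 fall within the usual scatter of this assay, so no order can be read between the two. Compound 3, by contrast, gives a clearly higher number, beyond the scatter, and is therefore the weaker inhibitor of the set.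

Compound 4 `CC(Sc1nc2c(cnn2C)c(=O)n1-c1ccccc1)c1ccncc1` has not yet been measured. It differs from compound 2 in a single place: pyridin-4-yl in place of pyridin-2-yl on a saturated chain carbon bound to a saturated chain carbon and a sulfur. The two compounds hold the same atoms, joined differently; only the position of the nitrogen within the pyridine ring changes. Among the compounds with values here, no pair of measured compounds here shows what such a change does, so a modest step in this assay is expected, if any, leaning slightly toward a weaker inhibitor. Compound 4 is estimated at 400 nM, with a plausible range from 150 nM to 1200 nM. The step this estimate implies is expected to be a 1.7-fold higher number from compound 2 to compound 4 (0.22 log units; within the scatter).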

Compound 4, half-maximal inhibitory concentration: 451 nM
The estimate for compound 4 lay 1.1-fold (0.05 log units) below the measured number; low and high end bracket the measured number.
By their numbers in this assay, from the lowest: compounds 1, 2 and 4 (each within the scatter of the next); then compound 3.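

In this assay the swap of pyridin-4-yl for pyridin-2-yl gives a 1.9-fold higher number from compound 2 to compound 4 (0.27 log units; within the scatter) and so leaves the two compounds indistinguishable in this assay. Within the data shown here, this is the first pair in the set that differs in one place only, and it shows that, on this saturated chain carbon and with this shared core, inhibition survives moving the nitrogen within the pyridine ring; this single pair says nothing about other cores or other groups at this position. No other measurement bears on this result, so nothing shown can say how the ring nitrogen's position relates to inhibition here.

The compounds shown leave open whether this position tolerates other ring arrangements, such as pyridin-3-yl, and whether a ring nitrogen is needed at all, which a plain phenyl ring in the same place would test. They also leave open how much the methyl group on the saturated chain carbon contributes, a question that a compound carrying hydrogen or a longer ethyl chain there could begin to answer.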